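Series notes: five-membered ring variation on the shared core

The compounds below may be only part of what the source reports. "The series", "measured", "known", "first", "only" and "open" are said of these compounds alone.

Measured so far:
compound 1 `c1coc(-c2ccccc2OCC2=NCCN2)c1`, 1.26 nM
compound 2 `c1ccc(-c2ccns2)c(OCC2=NCCN2)c1`, 5.01 nM

Both values come from a functional assay for activation of Alpha-1A adrenergic receptor (Homo sapiens), read by calcium flux; a lower number here means that less compound is needed, a higher number that more compound is needed for the effect. Compound 2 carries the highest of the two numbers; its nearest neighbour is compound 1, and the step of a 4.0-fold higher number from compound 1 to compound 2 (0.60 log units; beyond the scatter) lies beyond the scatter, a modest move.

Compound 3 `Cc1ccc(-c2ccccc2OCC2=NCCN2)s1` is not yet measured. Relative to compound 2 the change is 5-methylthiophen-2-yl in place of 1,2-thiazol-5-yl on an aromatic carbon, on the same aromatic carbon where the five-membered ring sits.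

Among the measured compounds shown here, only one measured step bears on this position, a 4.0-fold higher number from compound 1 to compound 2 (0.60 log units; beyond the scatter), which shows that swapping one five-membered ring for another at this carbon moves the number by a modest amount. For the measured compounds named here, the incoming 5-methylthiophen-2-yl ring, with one hetero atom, is counted closer to furan-2-yl than to 1,2-thiazol-5-yl; the added methyl is a new element with no measured precedent here. The expectation for compound 3 is therefore a return toward the number of compound 1, a step of a 2.5-fold lower number from compound 2 to compound 3 (0.40 log units; beyond the scatter), though the methyl leaves the range wide. Compound 3 is estimated at 2 nM, with a range from 0.6 nM to 7 nM.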

Compound 3, half-maximal effective concentration: 25.1 nM
Estimate against measurement, compound 3: 13-fold (1.10 log units) below; measured number above the stated range.
By their numbers in this assay, from the lowest: compound 1; then compound 2; then compound 3.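

In this assay, among the compounds shown here, the 5-methylthiophen-2-yl ring gives a 5.0-fold higher number from compound 2 to compound 3 (0.70 log units; beyond the scatter), and the comparison with the furan-2-yl ring gives a 20-fold higher number from compound 1 to compound 3 (1.30 log units; beyond the scatter), the only large step among the three compounds. Exchange of one five-membered ring for another at this aromatic carbon is therefore not limited to modest moves, and the count of hetero atoms does not order the series: compound 1 and compound 3, each with one hetero atom in the ring, fall on either side of compound 2, which has two. No measured information accounts for the rise at compound 3.

The ring change and the added methyl arrive together in compound 3, so the compounds shown cannot assign the rise to either one; a plain thiophen-2-yl or a 5-methylfuran-2-yl on the shared core would separate the two. Also open, on these data alone, is how an amine or a carboxylic acid on this carbon, in place of the five-membered ring, would read in this assay.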